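Para Substituent Swap on a Sulfonylated Pyrazoline Series

A few compounds are considered here, and "the series" means these few. Any claim that something is new, unique, unknown or untested is made for them only; others in the source may bear on it.

Compound 1 `CC(=O)N1N=C(c2ccc(N3CCN(C)CC3)cc2)CC1c1ccc(N(C)C)cc1`: -1.9%
Compound 2 `CN1CCN(c2ccc(C3=NN(S(=O)(=O)C4CC4)C(c4ccc(N(C)C)cc4)C3)cc2)CC1`: 0.2%
Compound 3 `CN1CCN(c2ccc(C3=NN(S(=O)(=O)c4ccc(C(F)(F)F)cc4)C(c4ccc(N(C)C)cc4)C3)cc2)CC1`: 18.9%

In a functional assay on NCI-H1975 cells (Homo sapiens) for inhibition, read by sulforhodamine B assay, tested at 10 uM (a lower number here means less inhibition, a higher number more inhibition at the concentration tested (going by the name of the read-out)), compound 3 stands highest of the three measured compounds. The step up to it reads a number 18.7 percentage points higher from compound 2 to compound 3 (beyond the scatter), and compound 1 lies further below still, while compound 1 and compound 2 differ by only a number 2.1 percentage points higher from compound 1 to compound 2 (within the scatter). Compound 4 `CN1CCN(c2ccc(C3=NN(S(=O)(=O)c4ccc(C#N)cc4)C(c4ccc(N(C)C)cc4)C3)cc2)CC1` is the next compound to be measured. It differs from compound 3 by cyano in place of trifluoromethyl on an aromatic carbon.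

For the measured compounds named here, of the measured steps, only the one from compound 2 to compound 3 bears on this change, since it shows what a para-substituted aryl sulfonyl brings against the cyclopropyl sulfonyl; no measured step exchanges one para substituent for another, so the data give no direct guide to the swap in compound 4. Because compound 3 already gives 18.9% with the aryl sulfonyl in place, compound 4 is expected to stay near it, with the step estimated as a number 3.9 percentage points lower from compound 3 to compound 4 (within the scatter), not beyond the scatter. Compound 4 is therefore estimated at 15%, in a range from 0% to 30%.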

Compound 4, a percentage reported as inhibition, at one concentration (the size of the read-out at that concentration, not a potency): 100%
For compound 4 the middle estimate is 85 percentage points below the measured one; the whole stated range lies below it.
By their numbers in this assay, from the lowest: compounds 1 and 2 (each within the scatter of the next); then compound 3; then compound 4.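

In this assay, for the compounds shown here, the substituent on the aromatic ring of the sulfonyl group proves decisive, which the earlier compounds could not show: cyano in place of trifluoromethyl, para to a large group, gives a number 81.1 percentage points higher from compound 3 to compound 4 (beyond the scatter). The aryl sulfonyl alone therefore does not set the level, and with the 4-cyanophenyl group the replacement of cyclopropyl gives a number 99.8 percentage points higher from compound 2 to compound 4 (beyond the scatter). Set against the acetyl group, the (4-cyanophenyl)sulfonyl group gives a number 101.9 percentage points higher from compound 1 to compound 4 (beyond the scatter), and nothing shown accounts for the size of these steps.

Going by these compounds, whether a nitro group, a carboxylic acid or a methoxy group at this place would give a similar reading remains open. A reading at one concentration also leaves the potency of compound 4 unknown, as it does whether the cyano gain holds with other groups on the shared core.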